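The source may report more compounds than this note shows. Statements on the series, on what has been measured and on what is new or still open speak of the compounds shown alone.

Measured so far in a physicochemical assay for lipophilicity, at pH 7.4; a higher number here means a more lipophilic compound, a lower number a more polar compound:
compound 1 `CC(C)CN(c1cccc(F)c1)S(=O)(=O)c1ccc2c(c1)C(O)CC(C1CCOCC1)O2` gives 3.39
compound 2 `Cc1ccc(N(C2CCC2)S(=O)(=O)c2ccc3c(c2)C(O)CC(C2CCOCC2)O3)c(C)c1` gives 3.77
compound 3 `CCc1ccc(N(C2COC2)S(=O)(=O)c2ccc3c(c2)C(O)CC(C2CCOCC2)O3)cc1` gives 2.63

Compound 1 stands second highest of the three in this assay. Compound 2 lies above it by a gap beyond the scatter, and compound 3 lies below it by a larger gap, also beyond the scatter. For the measured compounds named here, no two of these three compounds differ in a single place, so no measured step is at hand to lean on.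

Compound 4 `CC(C)CN(c1cc2ccccc2s1)S(=O)(=O)c1ccc2c(c1)C(O)CC(C1CCOCC1)O2` is not yet measured. It differs from compound 1 as follows: 1-benzothiophen-2-yl in place of 3-fluorophenyl on a sulfonamide nitrogen. Going by the values given here, the series holds no measured precedent for this exchange. The expected step is a number 1.01 log units higher from compound 1 to compound 4 (beyond the scatter), upward and beyond the scatter. Compound 4 is accordingly estimated at 4.4, with a range from 3.9 to 4.9.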

Compound 4, distribution coefficient: 3.92
Compound 4: the middle estimate sits 0.48 log units above what was measured; low and high end bracket the measured number.
By their numbers in this assay, from the lowest: compound 3; then compound 1; then compounds 2 and 4 (each within the scatter of the next).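

In this assay the exchange of 3-fluorophenyl for 1-benzothiophen-2-yl on a sulfonamide nitrogen gives a number 0.53 log units higher from compound 1 to compound 4 (beyond the scatter) with the rest of the molecule unchanged. For the compounds shown here, this is the first single-place step, and it shows that the aromatic group at this position can shift the number beyond the scatter. Nothing measured here explains the size of the step.

As far as these compounds go, whether the step carries over when the other nitrogen substituent changes remains open. So does the effect of a phenyl group bearing a carboxylic acid or an amine at this position.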